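A few compounds are considered here, and "the series" means these few. Any claim that something is new, unique, unknown or untested is made for them only; others in the source may bear on it.

Working notes on the benzyl-substituted series.

Of the compounds shown here, two carry a value so far. Compound 1 `Nc1n[nH]c2cc(-c3ccc(=O)n(Cc4ccccc4F)c3)ccc12` gives 12 nM in an assay for inhibition of MAP kinase-interacting serine/threonine-protein kinase 1 (Homo sapiens), read by luminescence and ADP-Glo, with a stated time of 2 h; a lower number here means a stronger inhibitor, a higher number a weaker inhibitor. Compound 2 `Nc1n[nH]c2cc(-c3ccc(=O)n(Cc4cccc(C(F)(F)F)c4)c3)ccc12` gives 56 nM in this assay. Compound 2 thus stands at the highest number of the two; its nearest neighbour is compound 1, whose number lies lower by a gap that is beyond the usual scatter of repeated runs. Among the compounds with values here, compound 1 and compound 2 differ at more than one place on the benzyl group, so no single step between measured compounds is available to lean on.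

The next compound, compound 3 `Nc1n[nH]c2cc(-c3ccc(=O)n(Cc4ccccc4)c3)ccc12`, removes the substituent from the benzyl ring of compound 2 altogether: hydrogen in place of trifluoromethyl on an aromatic carbon of a six-membered aromatic ring of carbon only, meta to a large group.

With no measured step of this kind in hand, the expectation rests only on compound 2 at 56 nM and compound 1 at 12 nM: a modest move toward a lower number in this assay is expected, roughly the step of a 2.2-fold lower number from compound 2 to compound 3 (0.35 log units; beyond the scatter), though a result within the scatter of compound 2 would not surprise. Compound 3 is estimated at 25 nM, with a plausible range from 8 nM to 80 nM.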

Compound 3, half-maximal inhibitory concentration: 79 nM
The estimate for compound 3 lay 3.2-fold (0.50 log units) below the measured number; measured number inside the range.
By their numbers in this assay, from the lowest: compound 1; then compounds 2 and 3 (each within the scatter of the next).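

In this assay, with the other parts of the molecule unchanged, hydrogen in place of trifluoromethyl on an aromatic carbon, meta to a large group, gives a 1.4-fold higher number from compound 2 to compound 3 (0.15 log units; within the scatter), so the numbers do not separate trifluoromethyl from hydrogen at this position. Hydrogen in place of fluoro on an aromatic carbon instead gives a 6.6-fold higher number from compound 1 to compound 3 (0.82 log units; beyond the scatter), the first single change in the series to lie beyond the scatter, and it places the fluoro compound apart from the unsubstituted benzyl compound. What underlies either step cannot be told from the data in hand.

Going by these compounds, because the fluoro and trifluoromethyl compounds differ from each other in more than one place, it stays open whether the contrast between these two steps follows the group itself or where it sits on the benzyl ring. On these data alone, it also stays open whether a chlorine atom, a methoxy group, a nitrile or an amine on this ring would track the fluoro step, the trifluoromethyl step or neither.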